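This account rests on a few compounds, and the source may have more. Where it says the series, first, only, none or still open, it means among the compounds named here.

Measured compounds and unmeasured partner in a functional assay on HT-29 cells (Homo sapiens) for cytotoxicity; a higher number here means a weaker inhibitor, a lower number a stronger inhibitor:

- compound 1 `COc1ccc(S(=O)(=O)N2CCc3cccc(NC(=O)c4cccs4)c32)cc1`: 37 nM
- compound 2 `COc1ccc(S(=O)(=O)N2CCc3cccc(NC(=O)c4ccncc4)c32)cc1`: 8.6 nM
- compound 3 `COc1ccc(S(=O)(=O)N2CCc3cccc(NC(=O)c4ccccc4)c32)cc1`: not yet measured

Of the two measured compounds, compound 2 stands lowest, with 8.6 nM, and so is the stronger inhibitor in this assay. The change now in question puts phenyl in place of pyridin-4-yl on a carbonyl carbon, turning the (pyridin-4-yl)carbonyl into a benzoyl: phenyl in place of pyridin-4-yl on a carbonyl carbon. Going by the values given here, only one measured step bears on this. It acts at the same place, where pyridin-4-yl replaced thiophen-2-yl, and it gave a 4.3-fold lower number from compound 1 to compound 2 (0.63 log units; beyond the scatter), a modest change beyond the scatter. Among the compounds with values here, no measured compound carries phenyl, so this single step is thin evidence. Since pyridin-4-yl gave the lower number in that one comparison, removing it is expected to raise the number by a similar modest amount, and the direction remains uncertain at the low end. The expected change is a 4.7-fold higher number from compound 2 to compound 3 (0.67 log units; beyond the scatter). For compound 3 the estimated value is 40 nM, with an expected range of 12 nM to 130 nM.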

Compound 3, half-maximal inhibitory concentration: 192 nM
The estimate for compound 3 lay 4.8-fold (0.68 log units) below the measured number; measured number outside the range, above it.
By their numbers in this assay, from the lowest: compound 2; then compound 1; then compound 3.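

In this assay, phenyl in place of pyridin-4-yl on the carbonyl carbon gave a 22-fold higher number from compound 2 to compound 3 (1.35 log units; beyond the scatter) and was a large step, although the two groups have the same heavy-atom count and differ in a single ring atom, carbon for nitrogen. The earlier comparison had set pyridin-4-yl against thiophen-2-yl, and phenyl in place of thiophen-2-yl now gives a 5.2-fold higher number from compound 1 to compound 3 (0.72 log units; beyond the scatter), which places compound 3 as the weakest of the three and compound 2 as the strongest, with every gap beyond the scatter. This place on the core therefore responds strongly to the identity of the aromatic ring on the carbonyl, and a six-membered aromatic ring alone does not preserve the low number of compound 2, but nothing at hand accounts for the size of the difference.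

Going by these compounds, it remains open whether the nitrogen must sit where pyridin-4-yl holds it, since pyridin-3-yl and pyridin-2-yl would test this directly. A pyrimidin-5-yl ring, or a phenyl ring carrying an amine, would show whether other nitrogen-bearing groups at this place can recover the number of compound 2.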